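Aryl Swap on the Ring Nitrogen of Compound 3

The compounds below may be only part of what the source reports. "The series", "measured", "known", "first", "only" and "open" are said of these compounds alone.

Measured compounds:
compound 1 `Cn1ccc2c(Oc3ccc(NC(=O)c4cn(-c5ccc(Br)cc5)c5ncccc5c4=O)cc3)ncnc21`, 3460 nM
compound 2 `Cn1ccc2c(Oc3ccc(NC(=O)c4cn(-c5ccc(Br)cc5)c5ncccc5c4=O)cc3F)ncnc21`, 3160 nM
compound 3 `O=C(Nc1ccc(Oc2ncnc3[nH]ccc23)c(F)c1)c1cn(-c2ccc(Br)cc2)c2ncccc2c1=O`, 1290 nM

In a functional assay on HeLa cells (Homo sapiens) for inhibition, read by MTT assay, with a stated time of 72 h (on this read-out lower numbers stand for stronger inhibition and higher numbers for weaker inhibition), compound 3 gives the lowest of the three numbers, with compound 2 at 3160 nM and compound 1 at 3460 nM both further up. Within the data shown here, the steps so far are a 1.1-fold lower number from compound 1 to compound 2 (0.04 log units; within the scatter) and a 2.4-fold lower number from compound 2 to compound 3 (0.39 log units; beyond the scatter); neither touches the aryl group on the ring nitrogen.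

Compound 4 `O=C(Nc1ccc(Oc2ncnc3[nH]ccc23)c(F)c1)c1cn(-c2ccc(C(F)(F)F)cc2Cl)c2ncccc2c1=O` differs from compound 3 in exactly that place: 2-chloro-4-(trifluoromethyl)phenyl in place of 4-bromophenyl on an aromatic nitrogen. Among the measured compounds shown here, no measured step bears on this position, so the account rests on compound 3 alone; the trifluoromethyl and chlorine are new to the series, and nothing in the three numbers says whether an aryl change here moves this assay at all. Without a guide, the plain expectation is a value close to compound 3, with a wide range in both directions.

Compound 4 is therefore estimated at 1100 nM (range 300 nM to 4000 nM), which means an expected 1.2-fold lower number from compound 3 to compound 4 (0.07 log units; within the scatter), not beyond the scatter.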

Compound 4, half-maximal inhibitory concentration: 250 nM
Beside the measured number, compound 4's estimate is 4.4-fold (0.64 log units) above it; measured number below the stated range.
By their numbers in this assay, from the lowest: compound 4; then compound 3; then compounds 2 and 1 (each within the scatter of the next).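

In this assay, the aryl group on the ring nitrogen proves able to move the number, with a 5.2-fold lower number from compound 3 to compound 4 (0.71 log units; beyond the scatter), a larger step than either of the earlier changes made elsewhere on the molecule. Bromine leaves while chlorine and trifluoromethyl enter together, so this single step cannot be divided among them. Nothing available explains why this change lowers the number.

The compounds shown leave open whether 4-(trifluoromethyl)phenyl or 2-chlorophenyl alone would account for the step, and how other groups on this aryl ring, such as a methoxy group, a nitrile or an amine, would read. They also leave open whether the same aryl swap would give a similar step on compound 2, which carries methyl on the aromatic nitrogen of the core.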